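Anilino in Place of Phenylsulfanyl: an Expectation for Compound 3

This account rests on a few compounds, and the source may have more. Where it says the series, first, only, none or still open, it means among the compounds named here.

Compound 1, `O=C(/C=C/c1ccc(O)c(O)c1)Nc1ccccc1Sc1ccccc1`: 27000 nM
Compound 2, `CC(=O)c1cccc(NC(=O)/C=C/c2ccc(O)c(O)c2)c1`: 10600 nM

In a functional assay, read by spectrophotometry, with a stated time of 30 min (on this read-out lower numbers stand for an effect already at smaller amounts and higher numbers for an effect only at larger amounts of compound), compound 1 gives the higher of the two numbers shown, and compound 2 gives a number that is lower by a margin beyond the scatter. Compound 3, `O=C(/C=C/c1ccc(O)c(O)c1)Nc1ccccc1Nc1ccccc1`, differs from compound 1 by anilino in place of phenylsulfanyl on an aromatic carbon. Among the measured compounds shown here, no step of this kind has been measured here, so the direction rests on the structures alone: the entering group is of equal size and carries one hydrogen-bond donor that the leaving group lacks. For compound 3 the step expected from compound 1 is a 1.4-fold lower number from compound 1 to compound 3 (0.13 log units; within the scatter), which means no change beyond the scatter. Compound 3 is estimated at 20000 nM, within a range from 7000 nM to 60000 nM.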

Compound 3, half-maximal effective concentration: 14700 nM
The estimate for compound 3 lay 1.4-fold (0.13 log units) above the measured number; the range from low to high includes it.
By their numbers in this assay, from the lowest: compounds 2, 3 and 1 (each within the scatter of the next, the first and the last beyond it).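

In this assay, anilino in place of phenylsulfanyl on an aromatic carbon, ortho to a large group, gives a 1.8-fold lower number from compound 1 to compound 3 (0.26 log units; within the scatter). The two groups have the same heavy-atom count, and the hydrogen-bond donor that anilino adds brings no difference that can be told from the scatter at this place. Nothing here gives a reason for this result. As far as these compounds go, it remains open whether a methylamino group or a carboxylic acid at this place would move the number beyond the scatter. A single step also cannot show whether this holds on other cores.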